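Shifting a Methyl Group on the Phenoxy Substituent

This account rests on a few compounds, and the source may have more. Where it says the series, first, only, none or still open, it means among the compounds named here.

Of the compounds shown here, three sharing one core have been measured for their ability to switch on the receptor in a functional assay on CHO cells for agonist activity at Free fatty acid receptor 1 (Homo sapiens), read by FLIPR and calcium flux, tested at 1 uM; on this read-out higher numbers stand for an effect only at larger amounts of compound and lower numbers for an effect already at smaller amounts. Compound 1, `O=C(O)CCc1ccc(NC(=O)c2nnc(COc3ccc(F)cc3)s2)cc1`, gives 5390 nM. Compound 2, `Cc1cccc(OCc2nnc(C(=O)Nc3ccc(CCC(=O)O)cc3)s2)c1`, gives 3260 nM. Compound 3, `CCc1ccc(OCc2nnc(C(=O)Nc3ccc(CCC(=O)O)cc3)s2)cc1`, gives 1170 nM, the lowest of the three numbers and therefore the one that acts at the smallest amount. The step of a 1.7-fold lower number from compound 1 to compound 2 (0.22 log units; within the scatter) stays within the usual scatter, whereas a 4.6-fold lower number from compound 1 to compound 3 (0.66 log units; beyond the scatter) and a 2.8-fold lower number from compound 2 to compound 3 (0.45 log units; beyond the scatter) both go beyond it, so the ethyl-bearing phenoxy group of compound 3 stands out.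

Compound 4, `Cc1ccccc1OCc1nnc(C(=O)Nc2ccc(CCC(=O)O)cc2)s1`, is built by the change (2-methylphenyl in place of 4-ethylphenyl on an oxygen on a saturated carbon). Among the measured compounds shown here, no measured pair shows exactly this move. The closest guide is a 2.8-fold lower number from compound 2 to compound 3 (0.45 log units; beyond the scatter), which shows that trading a 3-methylphenyl for a 4-ethylphenyl made the number smaller by a modest amount; reversing that direction, and shifting the methyl to the 2-position, is expected to undo part of that gain. Compound 4 is therefore expected to sit near compound 2, with the step of a 2.6-fold higher number from compound 3 to compound 4 (0.41 log units; beyond the scatter) pointing toward a higher number. The estimate for compound 4 in this assay is 3000 nM, with a plausible range from 1200 nM to 7500 nM.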

Compound 4, half-maximal effective concentration: 1520 nM
Estimate against measurement, compound 4: 2.0-fold (0.30 log units) above; low and high end bracket the measured number.
By their numbers in this assay, from the lowest: compounds 3 and 4 (each within the scatter of the next); then compounds 2 and 1 (each within the scatter of the next).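

In this assay, the 2-methylphenyl and 3-methylphenyl groups differ only in where the methyl sits, and that shift alone gives a 2.1-fold lower number from compound 2 to compound 4 (0.33 log units; beyond the scatter) on the same core, so the place of a single methyl on this ring can change the number. The larger 4-ethylphenyl group, with 8 heavy atoms, is not required to reach the low end of this small set: the 2-methylphenyl group, with 7 heavy atoms, gives a 1.3-fold higher number from compound 3 to compound 4 (0.11 log units; within the scatter) and the two compounds cannot be told apart. Measured against the 4-fluorophenyl group, the same 2-methylphenyl group gives a 3.5-fold lower number from compound 1 to compound 4 (0.55 log units; beyond the scatter) and so joins the 4-ethylphenyl group of compound 3 in lying beyond the scatter from compound 1.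

The compounds shown leave open how a phenyl with no substituent, or a methoxy group or a chlorine in place of the methyl on this ring, would compare with the 2-methylphenyl group. They also offer no measurement that explains the effect of moving the methyl, so its cause remains unknown.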